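This account rests on a few compounds, and the source may have more. Where it says the series, first, only, none or still open, it means among the compounds named here.

Of the compounds shown here, three built on one shared core have been measured in an assay on membranes from HEK293 cells for displacement of a labelled ligand from adenosine receptor A2b (Homo sapiens), read by scintillation counting, with a stated time of 30 min, tested at 1 uM; a lower number here means less inhibition, a higher number more inhibition at the concentration tested (going by the name of the read-out). Compound 1 `CC1=C(C(=O)OC(C)(C)C)C(c2ccsc2)NC(=O)N1` gives 47%. For the measured compounds named here, compound 2 `CC1=C(C(=O)C2CC2)C(c2ccsc2)NC(=O)N1` gives 1%, and the single recorded step, a number 46 percentage points lower from compound 1 to compound 2 (beyond the scatter), is large. Compound 3 `CC1=C(C(=O)SC(C)C)C(c2cccs2)NC(=O)N1` gives 1%, level with compound 2, so that the two sit together at the bottom of the three numbers, far under compound 1.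

Compound 4 `CC1=C(C(=O)SC(C)C)C(c2ccsc2)NC(=O)N1` has not yet been measured. It differs from compound 3 by thiophen-3-yl in place of thiophen-2-yl on a saturated ring carbon: the same atoms joined differently, on a saturated ring carbon of the shared core. Going by the values given here, no measured pair differs only in this way. Among the compounds with values here, compounds 1 and 2 both carry thiophen-3-yl yet differ from each other at the carbonyl carbon, and the one recorded step concerns that carbonyl group, not the ring. There is thus nothing to set a size from. Compound 2 carries thiophen-3-yl and gives 1%, so a low number seems most likely. Any change is expected to be small, a number 7 percentage points higher from compound 3 to compound 4 (within the scatter). Compound 4 is estimated at 8%, within 0% to 30%.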

Compound 4, a percentage reported as inhibition, at one concentration (the size of the read-out at that concentration, not a potency): 14%
The estimate for compound 4 lay 6 percentage points below the measured number; the measured number falls inside the stated range.
By their numbers in this assay, from the lowest: compounds 2 and 3 (each within the scatter of the next); then compound 4; then compound 1.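

In this assay, for the compounds shown here, exchanging thiophen-2-yl for thiophen-3-yl on the saturated ring carbon gives a number 13 percentage points higher from compound 3 to compound 4 (beyond the scatter), the first direct reading of this position, and it shows that a change in how the same atoms are joined can register here. With thiophen-3-yl held in place, the group on the carbonyl carbon can also be compared: isopropylsulfanyl in place of cyclopropyl gives a number 13 percentage points higher from compound 2 to compound 4 (beyond the scatter), while isopropylsulfanyl in place of tert-butoxy gives a number 33 percentage points lower from compound 1 to compound 4 (beyond the scatter). No measurement is available to explain these differences.

Going by these compounds, the ring step has been read only with isopropylsulfanyl on the carbonyl carbon, so its size alongside tert-butoxy or cyclopropyl remains unknown. Also open, on these data alone, is how a phenyl or pyridine ring on the saturated ring carbon would compare with either thiophene.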